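Compound 1 to compound 4: a swap on the carbonyl carbon

A few compounds are considered here, and "the series" means these few. Any claim that something is new, unique, unknown or untested is made for them only; others in the source may bear on it.

In a toxicity assay on THP-1 cells (Homo sapiens) for inhibition (a higher number here means that more compound is tolerated, a lower number that less compound is tolerated), compound 1 (`COc1ccc(-c2cnc(NC(=O)c3ncc[nH]3)n2C)cc1`) gives > 100000 nM as a limit of the assay and not a number. Compound 1 stands at the limit of > 100000 nM in this assay, at which 1 of the 3 values shown sits, and so has no number of its own. Compound 3 (`Cc1cccc(C(=O)Nc2ncc(-c3ccccc3)n2C)c1`) gives > 50000 nM as a limit too. For the measured compounds named here, compound 2 (`Cn1c(-c2ccc(Br)cc2)cnc1NC(=O)c1ccc(F)cc1`) gives 46000 nM as the one true number so far.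

Compound 4 (`COc1ccc(-c2cnc(NC(=O)c3cccnc3)n2C)cc1`) keeps the core of compound 1 and carries pyridin-3-yl in place of 1H-imidazol-2-yl on a carbonyl carbon. Going by the values given here, no measured pair isolates this change, so its size cannot be read directly. Compound 2 also has a six-membered aromatic ring on the carbonyl carbon and gives 46000 nM as a number, though it differs from compound 1 elsewhere as well. Compound 3 has such a ring too, and its > 50000 nM is again a limit. On that thin basis a modest step towards less compound tolerated is expected in this assay and the estimated step is (an at least 1.6-fold lower number from compound 1 to compound 4 (0.22 log units; that floor lies within the scatter)). For compound 4 the expected value is 60000 nM with an estimated range from 25000 nM to 100000 nM. There is a real chance that compound 4 will yield only a limit.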

Compound 4, half-maximal cytotoxic concentration: > 100000 nM
Compound 4 was reported as a limit; the forecaster's own chance of this, stated with the estimate: 55%; at least 1.6-fold (0.22 log units) between middle value and limit.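

In this assay compound 4 gives > 100000 nM, a limit of the assay and not a number. Compound 1 also stands at a limit, and the step between compound 1 and compound 4 cannot be read. The compounds shown leave open whether pyridin-3-yl in place of 1H-imidazol-2-yl on a carbonyl carbon changes the tolerated concentration at all, and by how much.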